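Iodo for methyl on the aryl side of compound 1

This account rests on a few compounds, and the source may have more. Where it says the series, first, only, none or still open, it means among the compounds named here.

Compound 1, `Cc1ccccc1NC(=O)N[C@H](C)c1ccccc1`, gives 100% in an ADME assay on the whole organism with Oryza sativa as the target, tested at 0.1 uM; a higher number here means a weaker effect of the compound at the concentration tested, a lower number a stronger effect.
Compound 2, `Cc1ccccc1NC(=O)N[C@@H](C)c1ccccc1`, gives 100%.
Compound 3, `CC(=O)c1cccc(NC(=O)N[C@H](C)c2ccccc2)c1`, gives 98%.

Compound 1 stands level with compound 2 at the digits shown, the two together the highest of the three numbers, and compound 3 gives a number within the scatter of both. Among the compounds with values here, the only measured step is no change at the digits printed from compound 1 to compound 2 (within the scatter), which rests on the fact that compounds 1 and 2 differ only in the configuration as drawn and so says nothing about a change on the aromatic ring. Compound 4, `C[C@@H](NC(=O)Nc1ccccc1I)c1ccccc1`, differs from compound 1 by iodo in place of methyl on an aromatic carbon. Within the data shown here, no measured step covers the exchange of a ring substituent, and all three numbers sit near the top of the scale. Compound 4 is therefore expected to give 97% (range 85% to 100%) in this assay. That estimate means a step of a number 3 percentage points lower from compound 1 to compound 4 (within the scatter), expected to be none beyond the scatter.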

Compound 4, a percentage reported as activity, at one concentration (the size of the read-out at that concentration, not a potency): 100%
Compound 4: the middle estimate sits 3 percentage points below what was measured, within the range that was stated.
By their numbers in this assay, from the lowest: compounds 3, 1, 2 and 4 (each within the scatter of the next).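

With this assay, iodo in place of methyl on an aromatic carbon ortho to a large group gives no change at the digits printed from compound 1 to compound 4 (within the scatter). Within the data shown here, this is the first reading of a change on the aromatic ring, as the earlier step concerned configuration alone, and at this position the exchange of carbon for iodine leaves the read-out where it was. Nothing at hand bears on why this exchange leaves the number unmoved. Still open, as far as these compounds go, is whether an amine, a carboxylic acid or a methoxy group at this position would move the number beyond the scatter.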